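The compounds below may be only part of what the source reports. "The series", "measured", "known", "first", "only" and "open" are said of these compounds alone.

Measured compounds:
compound 1 `O=C(Nc1ccccc1)Nc1ccc(Oc2ccc(-c3nccs3)cc2)cc1`, "not determined" (no result reported) in a functional assay on MDA-MB-231 cells (Homo sapiens) for inhibition, read by MTT assay and WST assay, with a stated time of 72 h, tested at 10 uM; on this read-out higher numbers stand for more inhibition of growth at the one concentration tested and lower numbers for less inhibition of growth;
compound 2 `O=C(Nc1ccc(Oc2ccc(-c3nccs3)cc2)cc1)Nc1ccc(Cl)c([N+](=O)[O-])c1`, 72.8%;
compound 3 `O=C(Nc1ccccc1)Nc1ccc(Oc2ccc(-c3ncc[nH]3)cc2)cc1`, 11.4%.

For the measured compounds named here, of the two numbers recorded, compound 3 stands lowest; the only other number, that of compound 2, lies far above it, well beyond the scatter, but the two compounds differ in more than one place and no single step connects them. Compound 4 `O=C(Nc1ccc(Oc2ccc(-c3ncc[nH]3)cc2)cc1)Nc1cccc(C(F)(F)F)c1` arises from compound 3 by the change (trifluoromethyl in place of hydrogen on an aromatic carbon), trifluoromethyl in place of hydrogen on an aromatic carbon. Going by the values given here, no pair of measured compounds shows this change, so its effect is not known here. The step from compound 3 to compound 4 is expected to be a moderate rise, a number 13.6 percentage points higher from compound 3 to compound 4 (beyond the scatter), of about the size of the scatter or slightly beyond it. Compound 4 is estimated at 25%, within 5% to 55%.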

Compound 4, percent growth inhibition at one concentration: 28.1%
Compound 4: middle estimate off by 3.1 percentage points, on the low side; low and high end bracket the measured number.
By their numbers in this assay, from the lowest: compound 3; then compound 4; then compound 2.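

The phenyl ring of compound 3 accepts trifluoromethyl on an aromatic carbon, and in this assay this single change gives a number 16.7 percentage points higher from compound 3 to compound 4 (beyond the scatter) as the first step read with the rest of the structure held constant. Growth inhibition therefore rises rather than falls with this change at this position. No measurement shown here bears on why the step goes this way. As far as these compounds go, it remains open whether an amine or a carboxylic acid at the same place would move the number in the same direction, and whether trifluoromethyl elsewhere on this ring would do so.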